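The source may report more compounds than this note shows. Statements on the series, on what has been measured and on what is new or still open speak of the compounds shown alone.

In a functional assay on MCF7 cells (Homo sapiens) for inhibition, read by sulforhodamine B assay, with a stated time of 48 h, tested at 50 uM (a lower number here means less inhibition of growth, a higher number more inhibition of growth at the concentration tested), two compounds sharing the same core have been measured so far. Compound 1 `CCCOc1ccc([C@@H]2CC(=O)c3cc(CC=C(C)C)c(OC)cc3O2)cc1` gives 60%. Compound 2 `COc1cc2c(cc1CC=C(C)C)C(=O)C[C@@H](c1ccc(Oc3ccc(F)cc3)cc1)O2` gives 37%, the lower of these two numbers. Compound 3 `COc1cc2c(cc1CC=C(C)C)C(=O)C[C@@H](c1ccc(Oc3cccc([N+](=O)[O-])c3)cc1)O2` keeps all of compound 2 except one group: 3-nitrophenyl in place of 4-fluorophenyl on an oxygen on an aromatic ring. In other words, 3-nitrophenyl stands in place of 4-fluorophenyl on an oxygen on an aromatic ring.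

Going by the values given here, only one measured step touches this same place, and it shows a number 23 percentage points lower from compound 1 to compound 2 (beyond the scatter). In that step, 4-fluorophenyl took the place of propyl. That is a change from a chain to a ring, whereas the new change swaps one substituted phenyl group for another, with the ring itself kept. The earlier step is therefore only a loose guide. Among the compounds with values here, no measured pair compares two such ring groups, so the data give no firm direction. On these data alone, a small change is the more likely outcome, though a wide range remains open. The expected step is a number 3 percentage points higher from compound 2 to compound 3 (within the scatter). For compound 3 the estimated value is 40%, with an expected range from 22% to 58%.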

Compound 3, percent growth inhibition at one concentration: 53%
The estimate for compound 3 lay 13 percentage points below the measured number; the range from low to high includes it.
By their numbers in this assay, from the lowest: compound 2; then compounds 3 and 1 (each within the scatter of the next).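

In this assay, the step of a number 16 percentage points higher from compound 2 to compound 3 (beyond the scatter) shows that the result at this oxygen depends on more than the presence of a phenyl ring, since 4-fluorophenyl and 3-nitrophenyl give clearly different numbers. The earlier step from propyl to 4-fluorophenyl could have suggested that a ring in this place costs growth inhibition in general, but the step of a number 7 percentage points lower from compound 1 to compound 3 (within the scatter) does not support that reading: 3-nitrophenyl and propyl cannot be told apart here, and compound 2 alone stands apart from the other two. Nothing measured explains why the two ring groups differ.

The two ring groups differ both in their substituent, fluorine against nitro, and in where it sits on the ring, so the numbers cannot separate these two changes. A plain phenyl group with no substituent would give a reference point for both rings, and a longer chain such as hexyl would show how the result at this oxygen changes beyond propyl.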